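The compounds below may be only part of what the source reports. "The series", "measured", "known", "first", "only" and "open" are said of these compounds alone.

Measured compounds: compound 1, `O=C(Nc1cccc2[nH]ncc12)NC1CCc2c(C3CC3)cccc21`, with 5 nM; compound 2, `O=C(Nc1cccc2[nH]ncc12)NC1CCc2cc(Br)ccc21`, with 9 nM.

Both numbers come from an assay on isolated protein for inhibition of transient receptor potential cation channel subfamily V member 1 (Homo sapiens), read by calcium flux; a higher number here means a weaker inhibitor, a lower number a stronger inhibitor. Of the two numbers shown, that of compound 2 is the larger, but compound 1 stands within the usual scatter of it, so the two cannot be told apart on these data. Compound 3, `O=C(Nc1cccc2[nH]ncc12)NC1CCc2cc(C(F)(F)F)ccc21`, has not been measured. It differs from compound 2 in one place: trifluoromethyl in place of bromo on an aromatic carbon. Within the data shown here, nothing measured so far shows how such a change behaves on this core, so the expectation rests on the closeness of compound 1 and compound 2 alone. In this assay the step expected is a 1.1-fold higher number from compound 2 to compound 3 (0.05 log units; within the scatter), none beyond the scatter, with a wide range to allow for the lack of any guide. In this assay compound 3 is therefore estimated at 10 nM, between 4 nM and 30 nM.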

Compound 3, half-maximal inhibitory concentration: 3 nM
Beside the measured number, compound 3's estimate is 3.3-fold (0.52 log units) above it; the measured number lies below the stated range.
By their numbers in this assay, from the lowest: compounds 3, 1 and 2 (each within the scatter of the next, the first and the last beyond it).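

In this assay, among these compounds, the change from bromo to trifluoromethyl on this aromatic carbon gives a 3.0-fold lower number from compound 2 to compound 3 (0.48 log units; beyond the scatter) and so provides the first step on this core that lies beyond the scatter, showing that the number responds to the group held at this position. Trifluoromethyl brings more heavy atoms than bromo and, like bromo, no hydrogen-bond donors or acceptors, yet the number falls rather than rises, so the position accepts the larger group on this evidence. Nothing available bears on why the step has this size.

Going by these compounds, whether the lower number is particular to trifluoromethyl or also holds for other groups on this carbon, such as a nitrile, a methoxy group or an amine, remains open. Also open, on these data alone, is whether the same change would give a similar step with a further substituent elsewhere on the shared core.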